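Branching the propyl chain on a benzamide series

The source may hold more compounds than are shown below. What is called first, only, known or untested is meant among the compounds shown, and "the series" means these compounds.

Compound 1 `Nc1ccccc1NC(=O)c1ccc(COc2ccccc2)cc1` gives 6700 nM in a functional assay on HepG2 cells (Homo sapiens) for antiproliferative activity, read by CCK-8 assay, with a stated time of 72 h; on this read-out higher numbers stand for weaker inhibition and lower numbers for stronger inhibition.
Compound 2 `CCCc1ccc(OCc2ccc(C(=O)Nc3ccccc3N)cc2)cc1` gives 4750 nM in this assay.
Compound 3 `Nc1cnccc1NC(=O)/C=C/c1ccc(COc2ccccc2)cc1` reaches only the limit > 32000 nM in this assay.

Among the measured compounds shown here, compound 2 stands at the lowest of the two numbers, though the only measured step, a 1.4-fold lower number from compound 1 to compound 2 (0.15 log units; within the scatter), lies within the scatter, so no order between the two can be claimed. Compound 4 `CC(C)c1ccc(OCc2ccc(C(=O)Nc3ccccc3N)cc2)cc1` differs from compound 2 by isopropyl in place of propyl on an aromatic carbon. For the measured compounds named here, no measured step alters the shape of this chain; the single step that added it was small. The expected step of a 1.1-fold higher number from compound 2 to compound 4 (0.02 log units; within the scatter) is therefore none beyond the scatter. Compound 4 is estimated at 5000 nM, with a range of 2000 nM to 12000 nM.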

Compound 4, half-maximal inhibitory concentration: > 32000 nM
Compound 4: no number, only a limit (the forecaster's own chance of this, stated with the estimate: 5%); middle value at least 6.4-fold (0.80 log units) away from the limit.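

Rearranging the same atoms from propyl to isopropyl at this position gives an at least 6.7-fold higher number from compound 2 to compound 4 (0.82 log units; beyond the scatter) in this assay, so here the shape of the chain matters and not only its presence. Isopropyl in place of hydrogen gives an at least 4.7-fold higher number from compound 1 to compound 4 (0.67 log units; beyond the scatter), whereas adding propyl stayed within the scatter. On these data alone, compound 4 has a limit and not a number, so the full size of both steps stays unknown: the limit of > 32000 nM in this assay, at which 2 of the 4 values shown sit.

As far as these compounds go, whether an ethyl, a tert-butyl or a longer straight chain at this position would behave like propyl or like isopropyl remains open.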